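Adding a Second Chloro to a Cytotoxic Purine-Like Scaffold

The compounds below may be only part of what the source reports. "The series", "measured", "known", "first", "only" and "open" are said of these compounds alone.

Compound 1 `ClCc1ccc(Cn2cnc3c(Cl)ncnc32)cc1` was tested in a functional assay on UACC-62 cells (Homo sapiens) for cytotoxicity, read by sulforhodamine B assay, with a stated time of 48 h (on this read-out higher numbers stand for weaker inhibition of growth and lower numbers for stronger inhibition of growth), and gives 1230 nM. Compound 2 `ClCc1cccc(Cn2cnc3c(Cl)nc(Cl)nc32)c1`, which carries its chloromethyl group elsewhere on the benzyl ring and a second chloro on the core, gives 1860 nM in this assay; the two numbers lie within the usual scatter of each other, so neither can be called the stronger. Compound 3 `ClCc1ccc(Cn2cnc3c(Cl)nc(Cl)nc32)cc1` differs from compound 1 by chloro in place of hydrogen on an aromatic carbon. Going by the values given here, no measured pair isolates this change, but compound 2 suggests little effect, so only a small step of a 1.2-fold higher number from compound 1 to compound 3 (0.09 log units; within the scatter) is expected, within the scatter. Compound 3 is estimated at 1500 nM, between 700 nM and 3500 nM.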

Compound 3, concentration for 50% growth inhibition: 2040 nM
Estimate against measurement, compound 3: 1.4-fold (0.13 log units) below; measured number inside the range.
By their numbers in this assay, from the lowest: compounds 1, 2 and 3 (each within the scatter of the next).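

Chloro in place of hydrogen on the aromatic carbon between two ring nitrogen atoms can now be read on its own: it gives a 1.7-fold higher number from compound 1 to compound 3 (0.22 log units; within the scatter) in this assay and so leaves no change that can be told apart from the scatter. This position therefore tolerates chloro in this assay, at least on the compound 1 framework. No available evidence explains this result. Still open, as far as these compounds go, is how a different group at this position, such as an amine or a methoxy group, would compare with hydrogen and chloro.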